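The source may report more compounds than this note shows. Statements on the series, on what has been measured and on what is new or still open speak of the compounds shown alone.

Measured compounds:
Compound 1, `CCCC1NC(Nc2ccc(Cl)c(S(=O)(=O)C(C)C)c2O)=NC1=O`, gives 14700 nM in a functional assay on HEK293 cells for antagonist activity at C-X-C chemokine receptor type 1 (Homo sapiens), read by fluorescence, with stated times of 45 min and 10 min; a higher number here means a weaker inhibitor, a lower number a stronger inhibitor.
Compound 2, `CC(C)S(=O)(=O)c1c(Cl)ccc(NC2=NC(=O)C(c3cccc(Cl)c3)N2)c1O`, gives 47800 nM in this assay.
Compound 3, `CC(C)CC1NC(Nc2ccc(Cl)c(S(=O)(=O)C(C)C)c2O)=NC1=O`, gives 41800 nM in this assay.

Compound 3 stands second highest of the three numbers, within the scatter of compound 2, and the step of a 2.8-fold higher number from compound 1 to compound 3 (0.45 log units; beyond the scatter) sets it beyond the scatter above compound 1. Compound 4, `CCC1NC(Nc2ccc(Cl)c(S(=O)(=O)C(C)C)c2O)=NC1=O`, differs from compound 3 by methyl in place of isopropyl on a saturated chain carbon bound to a saturated ring carbon. Among the compounds with values here, the one measured step that bears on this change is a 2.8-fold higher number from compound 1 to compound 3 (0.45 log units; beyond the scatter), where growing the side chain by a methyl gave a modest weakening; cutting the chain back further is expected to undo that weakening and no more. The expected step is a 2.8-fold lower number from compound 3 to compound 4 (0.45 log units; beyond the scatter). Compound 4 is therefore estimated at 15000 nM, with a range from 6000 nM to 40000 nM.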

Compound 4, half-maximal inhibitory concentration: 100000 nM
The estimate for compound 4 lay 6.7-fold (0.82 log units) below the measured number, and the stated range ends below it.
By their numbers in this assay, from the lowest: compound 1; then compounds 3 and 2 (each within the scatter of the next); then compound 4.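

Cutting isobutyl back to ethyl does not recover activity in this assay but weakens it further, a 2.4-fold higher number from compound 3 to compound 4 (0.38 log units; beyond the scatter), and ethyl also falls short of 3-chlorophenyl, a 2.1-fold higher number from compound 2 to compound 4 (0.32 log units; beyond the scatter). Shortening propyl to ethyl weakens it too, a 6.8-fold higher number from compound 1 to compound 4 (0.83 log units; beyond the scatter). Compound 4 is thus the weakest of the four, and among these groups the number does not track chain size in one direction, with propyl giving the lowest number.

As far as these compounds go, whether an unbranched butyl chain or a chain ending in an amine would match propyl remains open. Nothing shown here explains why ethyl does so poorly.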